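Methoxy in Place of Chloro and Brain Protein Binding

The compounds below may be only part of what the source reports. "The series", "measured", "known", "first", "only" and "open" are said of these compounds alone.

Three compounds share an amide linked to a small ring bearing a dichlorinated aromatic group, and each has been measured in an ADME assay on brain (Rattus norvegicus) for protein binding; a lower number here means a smaller unbound share, a higher number a larger unbound share of the compound. Compound 1 `Cc1nc2cnc(C(=O)NC3CN(c4cc(Cl)ncc4Cl)C3)cn2c1C` gives 0.034, compound 2 `Cc1c2cc(C(=O)NC3CN(c4cc(Cl)ncc4Cl)C3)ncc2nn1C` gives 0.03, and compound 3 `Cn1nnc2ccc(C(=O)NC3CN(c4cc(Cl)ncc4Cl)C3)cc21` gives 0.053. Compound 2 sits at the low end of these three, yet its gaps to compound 1 and to compound 3 both fall within the usual scatter of the measurement, so the three compounds are, on this read-out, indistinguishable. The step to compound 4 `COc1cc(N2CC(NC(=O)c3cc4c(C)n(C)nc4cn3)C2)c(Cl)cn1` changes the aromatic group itself: methoxy in place of chloro on an aromatic carbon. Among the compounds with values here, no pair of measured compounds shows this exchange, so its effect is unknown. The expectation, resting on how little the three measured values differ from one another, is a small rise in unbound fraction, giving a step of a 1.5-fold higher number from compound 2 to compound 4 (0.18 log units; within the scatter) that is expected to stay within the scatter. Compound 4 is therefore estimated at 0.045, with a range from 0.025 to 0.08.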

Compound 4, unbound fraction: 0.032
For compound 4 the middle estimate is 1.4-fold (0.15 log units) above the measured one, within the range that was stated.
By their numbers in this assay, from the lowest: compounds 2, 4, 1 and 3 (each within the scatter of the next).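

Replacing chloro with methoxy on the aromatic carbon next to the ring nitrogen turns the 2,5-dichloropyridin-4-yl group into 5-chloro-2-methoxypyridin-4-yl and gives, in this assay, a 1.1-fold higher number from compound 2 to compound 4 (0.03 log units; within the scatter). Within the data shown here, compounds 1, 2 and 3 differ only at the other end of the molecule, so this pair is the first to show that a change on the aromatic group itself, one that brings in a hydrogen-bond acceptor, can leave this read-out within the scatter. No measurement at hand explains why the value holds steady.

Going by these compounds, whether an amine or a longer chain such as ethoxy at this carbon would behave in the same way remains open. So does the outcome of the same exchange on the cores of compound 1 and compound 3.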